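Compound 3: phenyl in place of fluoro

This account rests on a few compounds, and the source may have more. Where it says the series, first, only, none or still open, it means among the compounds named here.

In a functional assay on Jurkat cells (Homo sapiens) for cytotoxicity, read by luminescence and CellTiter-Glo, with a stated time of 3 days (a higher number here means a weaker inhibitor, a lower number a stronger inhibitor), compound 1 (`O=C(Nc1ccc(C(F)(F)F)cc1)c1cc(Cl)ccc1O`) gives 710 nM and compound 2 (`O=C(Nc1ccc(C(F)(F)F)cc1)c1cc(Br)c(F)cc1O`) gives 880 nM with the two values within the usual scatter of each other. On these numbers compound 2 stands level with compound 1. Among the compounds with values here, the two structures differ in more than one place, so no single-place step is available to scale from.

The next structure is compound 3 (`O=C(Nc1ccc(C(F)(F)F)cc1)c1cc(Br)c(-c2ccccc2)cc1O`). Relative to compound 2, the change (phenyl in place of fluoro on an aromatic carbon) falls on an aromatic carbon, ortho to a bromo group, meta to a hydroxy group and para to a large group. Within the data shown here, the data hold no measured example of a phenyl at this place, so the expectation is uncertain in both directions. Among the measured compounds shown here, the only guide is the close agreement of compound 1 at 710 nM and compound 2 at 880 nM despite their structural differences. The estimate amounts to a 1.1-fold lower number from compound 2 to compound 3 (0.04 log units; within the scatter) and so to no expected change beyond the scatter. For compound 3 the estimated value in this assay is 800 nM with a range from 250 nM to 2500 nM expected for the measurement.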

Compound 3, half-maximal inhibitory concentration: 740 nM
The estimate for compound 3 lay 1.1-fold (0.03 log units) above the measured number; low and high end bracket the measured number.
By their numbers in this assay, from the lowest: compounds 1, 3 and 2 (each within the scatter of the next).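

In this assay, within the data shown here, placing phenyl instead of fluoro on this aromatic carbon, ortho to a bromo group, meta to a hydroxy group and para to a large group, gives a 1.2-fold lower number from compound 2 to compound 3 (0.08 log units; within the scatter) and so supplies the first single-place step. Going from 1 heavy atom to 6 heavy atoms, with one six-membered aromatic ring of carbon only entering, therefore leaves the read-out within the scatter for this pair, so this position can carry a phenyl in the setting of compound 2 without a step beyond the scatter. The data hold nothing that gives a reason for this result.

Fluoro and phenyl both count 0 hydrogen-bond donors, 0 hydrogen-bond acceptors and no net charge, so it remains open whether an amine or a carboxylic acid on this carbon would also stay within the scatter of compound 2. Also open, on these data alone, is whether a longer alkyl chain would read like the phenyl, and whether the step from fluoro to phenyl would be the same with chloro in place of bromo, as in the core of compound 1.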